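Rearranging the aryl terminus of an oxazole ketone inhibitor

The source may report more compounds than this note shows. Statements on the series, on what has been measured and on what is new or still open speak of the compounds shown alone.

Measured compounds:
compound 1 `O=C(CCCCCCc1ccccn1)c1ncc(-c2ccccn2)o1` — 120 nM
compound 2 `O=C(CCCCCCc1ccc(Cl)cc1)c1ncc(-c2ccccn2)o1` — 2.7 nM
compound 3 `Nc1ccc(CCCCCCC(=O)c2ncc(-c3ccccn3)o2)cc1` — 3 nM

In an assay for inhibition of Fatty-acid amide hydrolase 1 (Rattus norvegicus) (a higher number here means a weaker inhibitor, a lower number a stronger inhibitor), compound 3 stands second highest of the three numbers. Its nearest neighbour is compound 2, from which it is separated by a 1.1-fold higher number from compound 2 to compound 3 (0.05 log units; within the scatter). The furthest is compound 1, whose number is higher by a 40-fold lower number from compound 1 to compound 3 (1.60 log units; beyond the scatter).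

Compound 4 `CN(CCCCCC(=O)c1ncc(-c2ccccn2)o1)c1ccccc1` differs from compound 3 by methyl(phenyl)amino in place of 4-aminobenzyl on a saturated chain carbon, five bonds along the chain from a carbonyl carbon. Among the measured compounds shown here, no measured step is of this kind. The steps of a 44-fold lower number from compound 1 to compound 2 (1.65 log units; beyond the scatter) and a 40-fold lower number from compound 1 to compound 3 (1.60 log units; beyond the scatter) show that the identity of the terminal aromatic group can move this assay strongly, whereas a 1.1-fold higher number from compound 2 to compound 3 (0.05 log units; within the scatter) shows that swapping the substituent on that ring does not. Moving the nitrogen into the chain and removing one chain carbon is a different change, so its outcome is uncertain; the expectation is a modest weakening, a 5.0-fold higher number from compound 3 to compound 4 (0.70 log units; beyond the scatter). Compound 4 is therefore estimated at 15 nM, in a range from 3 nM to 80 nM.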

Compound 4, inhibition constant: 40 nM
Beside the measured number, compound 4's estimate is 2.7-fold (0.43 log units) below it; measured number inside the range.
By their numbers in this assay, from the lowest: compounds 2 and 3 (each within the scatter of the next); then compound 4; then compound 1.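

Compound 4 keeps a carbon-only aromatic ring, yet the rearranged terminus gives a 13-fold higher number from compound 3 to compound 4 (1.12 log units; beyond the scatter) and a 15-fold higher number from compound 2 to compound 4 (1.17 log units; beyond the scatter) in this assay, both large, whereas the substituent swap on the ring had stayed within the scatter. This position therefore responds to how the terminal ring is joined to the chain, and not only to the identity of the ring, although compound 4 still improves on the pyridin-2-yl terminus, with a 3.0-fold lower number from compound 1 to compound 4 (0.48 log units; beyond the scatter), a modest step. No measurement shown here accounts for these differences.

As far as these compounds go, the step changes the chain nitrogen, its methyl, the chain length and the ring's 4-amino or 4-chloro substituent together, so their separate contributions remain open. A phenylamino group without the methyl, or a longer chain carrying methyl(phenyl)amino, would begin to separate them.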